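A few compounds are considered here, and "the series" means these few. Any claim that something is new, unique, unknown or untested is made for them only; others in the source may bear on it.

Going by the values given here, compound 1 `Cc1cccc2c1cnn2-c1ccc(NC(=O)Nc2ccc(Cl)c(C(F)(F)F)c2)cc1` is one of only two compounds measured in a functional assay on NCI-H460 cells (Homo sapiens) for cytotoxicity, read by MTT assay, with a stated time of 72 h; a higher number here means a weaker inhibitor, a lower number a stronger inhibitor. In this assay compound 1 gives 2500 nM, and compound 2 `COc1cccc2c1cnn2-c1ccc(NC(=O)Nc2ccc(Cl)c(C(F)(F)F)c2)cc1` gives 2200 nM. Among the compounds with values here, the single step available, a 1.1-fold lower number from compound 1 to compound 2 (0.06 log units; within the scatter), corresponds to a methoxy in place of methyl on an aromatic carbon.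

Compound 3 `O=C(Nc1ccc(-n2ncc3cccnc32)cc1)Nc1ccc(Cl)c(C(F)(F)F)c1` has not yet been measured. It differs from compound 1 by a group of 9 heavy atoms (6 carbon, 3 nitrogen; one five-membered aromatic ring with 2 hetero atoms, one six-membered aromatic ring with 1 hetero atom) in place of a group of 10 heavy atoms (8 carbon, 2 nitrogen; one five-membered aromatic ring with 2 hetero atoms, one six-membered aromatic ring of carbon only), on an aromatic carbon. Within the data shown here, the one measured step is of a different kind, a change of a small substituent rather than replacement of the entire 4-methyl-1H-indazol-1-yl group, and it lay within the scatter, so it offers no guide to the direction of the new change. No step beyond the scatter is expected either way, and the estimate rests on compound 1 alone, with a wide range.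

Compound 3 is therefore expected to give 3000 nM, between 1000 nM and 9000 nM. The expected step is a 1.2-fold higher number from compound 1 to compound 3 (0.08 log units; within the scatter).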

Compound 3, half-maximal inhibitory concentration: 16600 nM
The estimate for compound 3 lay 5.5-fold (0.74 log units) below the measured number, outside the stated range (above it).
By their numbers in this assay, from the lowest: compounds 2 and 1 (each within the scatter of the next); then compound 3.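

In this assay, going by these compounds alone, the exchange of the 4-methyl-1H-indazol-1-yl group on this aromatic carbon, para to a large group, gives a 6.6-fold higher number from compound 1 to compound 3 (0.82 log units; beyond the scatter), the first step here to lie beyond the scatter. The earlier change, a 1.1-fold lower number from compound 1 to compound 2 (0.06 log units; within the scatter), lay within the scatter, so the result shows that the number at this position can respond to a change in the group as a whole, even though a swap of methyl for methoxy did not move it beyond the scatter. Nothing available explains this step.

As far as these compounds go, the change removes the methyl and places a hetero atom in the six-membered aromatic ring at once, so the share of each in the step remains open. Also open, from the compounds shown here alone, is how an amine or a chlorine in place of that methyl would read in this assay, and whether either would stay within the scatter of compound 1.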